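Compound 3: fluorocyclobutyl replaces methoxycyclohexyl

The compounds below may be only part of what the source reports. "The series", "measured", "known", "first", "only" and "open" are said of these compounds alone.

Within the data shown here, in an ADME assay on microsomes from liver (Homo sapiens) for metabolic stability, read by LC-MS, using NADPH, with a stated time of 10 min, tested at 10 uM (a higher number here means that the compound lasts longer, a lower number that the compound disappears faster), compound 2 (`CO[C@H]1CC[C@@H](n2nc(Oc3cc(C(F)(F)F)ccn3)c3c(N)ncnc32)CC1`) gives 0.317 h as the only exact number so far. Compound 1 (`Nc1ncnc2c1c(Oc1cc(C(F)(F)F)ccn1)nn2[C@H]1CC[C@@H](N)CC1`) reads > 2.41 h as a limit of the assay. Among the measured compounds shown here, the one measured step (an at least 7.6-fold lower number from compound 1 to compound 2 (0.88 log units; beyond the scatter)) was methoxy in place of amino on a saturated ring carbon. Compound 3 (`Nc1ncnc2c1c(Oc1cc(C(F)(F)F)ccn1)nn2[C@H]1C[C@H](F)C1`) has 3-fluorocyclobutyl in place of 4-methoxycyclohexyl on an aromatic nitrogen, so the methoxy leaves. That single step is only a loose guide, and a modest rise is expected in this assay for this change. The expected step (a 1.9-fold higher number from compound 2 to compound 3 (0.28 log units; within the scatter)) is upward. Compound 3 is estimated at 0.6 h (range 0.2 h to 1.8 h) on this read-out.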

Compound 3, half-life: 2.03 h
For compound 3 the middle estimate is 3.4-fold (0.53 log units) below the measured one; measured number outside the range, above it.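

In this assay, a long half-life at this position does not need the amino group of compound 1: 3-fluorocyclobutyl in place of 4-methoxycyclohexyl on the aromatic nitrogen gives a 6.4-fold higher number from compound 2 to compound 3 (0.81 log units; beyond the scatter). The change from 4-aminocyclohexyl gives an at least 1.1-fold lower number from compound 1 to compound 3 (0.07 log units; that floor lies within the scatter); this comparison rests on a limit of the assay, so it sets no order between the two compounds. The step to compound 3 changes ring size and swaps methoxy for fluorine at once, and the compounds shown do not separate the two. From the compounds shown here alone, how a plain cyclobutyl or a 4-fluorocyclohexyl on the same nitrogen would read remains open.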